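This account rests on a few compounds, and the source may have more. Where it says the series, first, only, none or still open, it means among the compounds named here.

In a functional assay on UACC-62 cells (Homo sapiens) for inhibition, read by sulforhodamine B assay, with a stated time of 48 h (a higher number here means that more compound is tolerated, a lower number that less compound is tolerated), compound 3 (`COc1cc(-c2nn(-c3cccc(NC(=O)Nc4ccc(Cl)c(Cl)c4)c3)cc2-c2ccncc2)ccc1Cl`) gives 4490 nM, the second highest of the three numbers measured. Compound 2 (`COc1cc(-c2nn(-c3cccc(NC(=O)Nc4cc(C(F)(F)F)cc(C(F)(F)F)c4)c3)cc2-c2ccncc2)ccc1Cl`) gives 3780 nM, and the two values lie within the scatter of each other, so nothing separates them. Compound 1 (`O=C(Nc1cccc(-n2cc(-c3ccncc3)c(-c3ccc(Cl)c(O)c3)n2)c1)Nc1cccc(C(F)(F)F)c1`) gives 21900 nM, a number beyond the scatter away from compound 3.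

Compound 4 (`COc1cc(-c2nn(-c3cccc(NC(=O)Nc4cccc(C(F)(F)F)c4)c3)cc2-c2ccncc2)ccc1Cl`) differs from compound 3 in one place: 3-(trifluoromethyl)phenyl in place of 3,4-dichlorophenyl on an amide-type nitrogen. Going by the values given here, no step between two measured compounds shows this exact exchange on the same core, so the expectation rests on the neighbours. Compound 1 carries the same 3-(trifluoromethyl)phenyl on a different core and gives 21900 nM, while compound 2 carries two trifluoromethyl groups and gives 3780 nM. For compound 4 the step of a 1.4-fold higher number from compound 3 to compound 4 (0.16 log units; within the scatter) is expected to run toward a higher number, but of a size that need not exceed the scatter. Compound 4 is therefore estimated at 6500 nM, with a range from 2500 nM to 17000 nM.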

Compound 4, concentration lethal to 50% of the cells: 3480 nM
For compound 4 the middle estimate is 1.9-fold (0.27 log units) above the measured one; the range from low to high includes it.
By their numbers in this assay, from the lowest: compounds 4, 2 and 3 (each within the scatter of the next); then compound 1.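

In this assay the swap of 3,4-dichlorophenyl for 3-(trifluoromethyl)phenyl on the amide-type nitrogen stays within the scatter (a 1.3-fold lower number from compound 3 to compound 4 (0.11 log units; within the scatter)), and so does hydrogen in place of trifluoromethyl on an aromatic carbon of that ring (a 1.1-fold lower number from compound 2 to compound 4 (0.04 log units; within the scatter)). On the shared core, then, these three aryl groups on the nitrogen are not told apart. Going by these compounds alone, the only step beyond the scatter lies at the other end of the molecule: methyl in place of hydrogen on an oxygen on an aromatic ring (a 6.3-fold lower number from compound 1 to compound 4 (0.80 log units; beyond the scatter)) shows that the gap to compound 1 goes with that oxygen and not with the aryl group. Nothing shown explains either the flat position or this step. Still open, on these data alone, is whether an amine or a carboxylic acid on the aryl ring, or a longer chain on the oxygen, would move the number.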